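Chloro in Place of Bromo on the Pendant Phenyl

The source may hold more compounds than are shown below. What is called first, only, known or untested is meant among the compounds shown, and "the series" means these compounds.

Measured so far:
compound 1, `Cc1cc(O)c(C(=O)/C=C/c2ccc(F)cc2)c(-c2ccccc2)c1C(=O)/C=C/c1ccc(F)cc1`; in a functional assay on MDA-MB-231 cells (Homo sapiens) for cytotoxicity, read by MTT assay, with a stated time of 24 h (on this read-out higher numbers stand for weaker inhibition and lower numbers for stronger inhibition), compound 1 gives 20000 nM
compound 2, `Cc1cc(O)c(C(=O)/C=C/c2ccccc2)c(-c2ccc(Br)cc2)c1C(=O)/C=C/c1ccccc1`; in this assay compound 2 gives 8000 nM

Of the two numbers shown, compound 2 has the lower one, and its nearest neighbour is compound 1, whose higher number lies beyond the usual scatter of this read-out. Within the data shown here, the two compounds differ in more than one place, so what their two values show is only that compound 2 comes out ahead.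

The next compound to be tested, compound 3 `Cc1cc(O)c(C(=O)/C=C/c2ccccc2)c(-c2ccc(Cl)cc2)c1C(=O)/C=C/c1ccccc1`, differs from compound 2 in one place only: chloro in place of bromo on an aromatic carbon, para to a large group; cut one bond further out, the change reads 4-bromophenyl to 4-chlorophenyl. Among the measured compounds shown here, no pair of measured compounds separated by a single change is available, so nothing here tells how such an exchange has behaved before.

On that footing the step is expected to be small, most likely none beyond the scatter, with a slight lean toward a higher number. Compound 3 is expected to give 10000 nM in this assay, within a range of 4000 nM to 25000 nM. The expected step is a 1.3-fold higher number from compound 2 to compound 3 (0.10 log units; within the scatter).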

Compound 3, half-maximal inhibitory concentration: 4400 nM
Beside the measured number, compound 3's estimate is 2.3-fold (0.36 log units) above it, and the stated range covers the measured number.
By their numbers in this assay, from the lowest: compounds 3 and 2 (each within the scatter of the next); then compound 1.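

In this assay, among these compounds, the exchange of bromo for chloro on the aromatic carbon para to a large group gives a 1.8-fold lower number from compound 2 to compound 3 (0.26 log units; within the scatter), which makes this the first comparison to isolate a single change. The earlier pair could not speak to this position, since compound 1 and compound 2 differ in more than one place, whereas here the two halogens cannot be told apart on this read-out, and the 4-bromophenyl and 4-chlorophenyl groups stand as interchangeable within the usual scatter of repeated measurements. Nothing measured on these compounds offers an explanation for this result, and none is attempted here.

This single exchange between two halogens says nothing about how far the position tolerates other kinds of group, such as an amine, a methoxy group or a carboxylic acid, or about what the ring would give with a plain hydrogen there and all else held as in compound 2. From the compounds shown here alone, whether the same exchange would behave alike on the other aromatic rings of the shared core also remains open.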